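The compounds below may be only part of what the source reports. "The series", "measured", "known", "first", "only" and "open" are said of these compounds alone.

Compound 2 `CC(C)n1ncc2c(C(=O)Nc3ncccn3)cc(-c3ccsc3)nc21` gives 50000 nM in an ADME assay on LLC-MK2 cells (Macaca mulatta) for cytotoxicity, read by spectrophotometry and crystal violet staining, with a stated time of 4 days (a higher number here means that more compound is tolerated, a lower number that less compound is tolerated), and compound 3 `CC(C)n1ncc2c(C(=O)Nc3ccccn3)cc(-c3ccsc3)nc21` gives 25000 nM there. Within the data shown here, these are the only two numbers so far, and a 2.0-fold lower number from compound 2 to compound 3 (0.30 log units; within the scatter) keeps them within the scatter of each other. Compound 1 `CC(C)n1ncc2c(C(=O)Nc3ccc(F)cc3)cc(-c3cccs3)nc21` also carries 4-fluorophenyl on the amide-type nitrogen and gives > 200000 nM in this assay, which is a limit of the assay and not a number.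

Compound 4 `CC(C)n1ncc2c(C(=O)Nc3ccc(F)cc3)cc(-c3ccsc3)nc21` follows from compound 3 by 4-fluorophenyl in place of pyridin-2-yl on an amide-type nitrogen.

Among the measured compounds shown here, the one measured step at this nitrogen is a 2.0-fold lower number from compound 2 to compound 3 (0.30 log units; within the scatter), which stays within the scatter and involves no 4-fluorophenyl. It therefore says little about the size of the coming step. The only hint on direction comes from compound 1 and (the limit of > 200000 nM in this assay, at which 1 of the 3 values shown sits), so a move towards more compound tolerated is expected, though on thin evidence. The estimated step is a 4.0-fold higher number from compound 3 to compound 4 (0.60 log units; beyond the scatter), and a reading at the assay limit would not be a surprise. For compound 4 the expected value is 100000 nM, with an estimated range of 35000 nM to 200000 nM.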

Compound 4, half-maximal cytotoxic concentration: > 200000 nM
Compound 4: only a limit was reported; the forecaster's own chance of this, stated with the estimate: 40%; middle value at least 2.0-fold (0.30 log units) away from the limit.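

In this assay, the change at the amide-type nitrogen now has a step beyond the scatter: 4-fluorophenyl in place of pyridin-2-yl gives an at least 8.0-fold higher number from compound 3 to compound 4 (0.90 log units; beyond the scatter), and 4-fluorophenyl in place of pyrimidin-2-yl gives an at least 4.0-fold higher number from compound 2 to compound 4 (0.60 log units; beyond the scatter). The earlier exchange between the two nitrogen-containing rings showed no such separation, so in this small set the larger difference appears only when the carbon-only ring with fluorine enters. The step between compound 1 and compound 4, thiophen-3-yl in place of thiophen-2-yl on an aromatic carbon, cannot be read, so the thiophene attachment adds nothing here, and the size of the new steps has only a lower bound: the limit of > 200000 nM in this assay, at which 2 of the 4 values shown sit.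

The compounds shown do not separate the loss of the ring nitrogen from the gain of the fluorine, and an unsubstituted phenyl on the amide-type nitrogen would bear directly on that. On these data alone, it also remains open whether a 4-methoxyphenyl, a 4-aminophenyl or a saturated ring such as cyclohexyl at this nitrogen would stay at the limit or give a readable number.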